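Swapping pyridin-3-yl for 4-chlorophenyl on the shared core

This account rests on a few compounds, and the source may have more. Where it says the series, first, only, none or still open, it means among the compounds named here.

The three measured compounds were all tested in an assay for inhibition of Polyunsaturated fatty acid lipoxygenase ALOX15 (Homo sapiens), with a stated time of 10 min; on this read-out lower numbers stand for stronger inhibition and higher numbers for weaker inhibition.
Compound 1 `Nc1[nH]c(C(=O)c2ccccc2)c(-c2cccnc2)c1C(=O)c1cccc(Cl)c1` gives > 100000 nM in this assay, which is a limit of the assay rather than a number.
Compound 2 `CCOC(=O)c1ccc(N)[nH]1` gives > 100000 nM, again a limit.
Compound 3 `Nc1[nH]c(C(=O)c2ccccc2)c(-c2c(F)cccc2F)c1C(=O)c1ccc(Cl)c(Cl)c1` gives > 100000 nM, also a limit.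

So compound 1 does not stand apart from the others on the numbers shown: every value sits at the limit of > 100000 nM in this assay, at which 3 of the 3 values shown sit, and no step between two measured compounds can be counted. Nothing here separates the core of compound 1 from the far smaller compound 2 or from compound 3.

Compound 4 `Nc1[nH]c(C(=O)c2ccccc2)c(-c2ccc(Cl)cc2)c1C(=O)c1cccc(Cl)c1` has not yet been measured in this assay. It differs from compound 1 in one place: 4-chlorophenyl in place of pyridin-3-yl on an aromatic carbon. Among the compounds with values here, with no measured step to lean on, the expectation for this change is no shift beyond the usual scatter in this assay. For compound 4 the estimated result is 100000 nM, within a range from 30000 nM to 300000 nM, most likely reported again as a limit. That estimate means a step of a number no higher from compound 1 to compound 4 (the limit leaves the size open) that is expected to be too small to see.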

Compound 4, half-maximal inhibitory concentration: > 100000 nM
Compound 4: a limit, no number; the forecaster's own chance of this, stated with the estimate: 70%; the middle value sits exactly at the limit.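

Compound 4 gives > 100000 nM, which is a limit and not a number. Compound 1 is also a limit, so no step from compound 1 to compound 4 can be read: the limit of > 100000 nM in this assay, at which 4 of the 4 values shown sit.

The compounds shown leave open which change to the shared core, if any, would give a measurable value.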